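The compounds below may be only part of what the source reports. "The series", "measured", "known", "first", "only" and "open" are said of these compounds alone.

Measured so far:
- compound 1, `COc1ccc(-c2coc3cc(O)cc(O)c3c2=O)cc1O`: in a functional assay on BV-2 cells (Mus musculus) for inhibition (on this read-out higher numbers stand for weaker inhibition and lower numbers for stronger inhibition), compound 1 gives 26300 nM.
- compound 2, `COc1ccc(-c2coc3c(-c4c(OC)cc([C@@H]5OO[C@@H]5CO)cc4OC)c(O)ccc3c2=O)cc1O`: compound 2 gives 9000 nM.
- compound 3, `COc1cc(-c2coc3cc(O)cc(O)c3c2=O)ccc1O`: compound 3 gives only > 50000 nM, which is a limit of the assay and not a number.

Compound 3 thus stands at the edge of what this assay reports: its reading sits at the limit of > 50000 nM in this assay, at which 1 of the 3 values shown sits, so no number is known for it. For the measured compounds named here, compound 1 and compound 2 give numbers; compound 2 gives the lower of the two, and no connecting step between them has been worked out.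

The next compound is compound 4, `COc1cc(-c2coc3cc(O)ccc3c2=O)ccc1O`. It differs from compound 3 by hydrogen in place of hydroxy on an aromatic carbon. Going by the values given here, no comparable step is available among the measured compounds, so nothing measured indicates a direction. Removing a hydroxy group from a compound that already reads out at the limit is not expected to lift it into the measurable range; a step of no more than the scatter, or a further weakening, is anticipated.

Compound 4 is therefore estimated at 60000 nM, with a range from 20000 nM to 200000 nM. The step expected is a step that the limit leaves unreadable from compound 3 to compound 4, with a strong chance that compound 4 is again reported only as a limit.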

Compound 4, half-maximal inhibitory concentration: 39800 nM
Beside the measured number, compound 4's estimate is 1.5-fold (0.18 log units) above it, and the stated range covers the measured number.
By their numbers in this assay, from the lowest: compound 2; then compounds 1 and 4 (each within the scatter of the next). At a limit, above all of these: compound 3.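

In this assay, for the compounds shown here, hydrogen in place of hydroxy on this aromatic carbon, ortho to a fused ring and meta to a fused ring, gives the first readable step, an at least 1.2-fold lower number from compound 3 to compound 4 (0.09 log units; that floor lies within the scatter). Compound 3 stands at a limit and not a number, and only a floor of this step can be read: the limit of > 50000 nM in this assay, at which 1 of the 4 values shown sits. Compound 4 gives 39800 nM, a measured number, which shows that a reading within the measurable range survives the loss of this hydroxy group.

From the compounds shown here alone, the true size of the step stays open, and with it whether this change does more than the scatter allows. Also open, going by these compounds, is what an amine, a fluorine atom or a carboxylic acid would give on this aromatic carbon in place of the hydrogen of compound 4.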